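Cytotoxicity notes: N-methyl removal in the benzimidazole-linked amide series

A few compounds are considered here, and "the series" means these few. Any claim that something is new, unique, unknown or untested is made for them only; others in the source may bear on it.

Measured so far:
compound 1 `Oc1ccc(-c2nc3cc(C(F)(F)F)ccc3[nH]2)cc1` — > 100000 nM
compound 2 `CCN(CC)CC(=O)Nc1ccc(-c2nc3cc(C(F)(F)F)ccc3n2C)cc1` — 16000 nM

In an ADME assay on BHK cells (Mesocricetus auratus) for cytotoxicity, read by MTT assay, with a stated time of 96 h (a lower number here means that less compound is tolerated, a higher number that more compound is tolerated), compound 1 gives only a limit, > 100000 nM. In this assay, for the measured compounds named here, compound 2 gives 16000 nM, the only number recorded. The entry of compound 1 sits at the limit, as noted (the limit of > 100000 nM in this assay, at which 1 of the 2 values shown sits). Compound 3 `CCN(CC)CC(=O)Nc1ccc(-c2nc3cc(C(F)(F)F)ccc3[nH]2)cc1` differs from compound 2 by hydrogen in place of methyl on an aromatic nitrogen. Going by the values given here, no step between two measured compounds is known for this change, so its size is uncertain. A modest shift toward greater tolerance is expected from compound 2 to compound 3, a 1.9-fold higher number from compound 2 to compound 3 (0.27 log units; within the scatter), within or near the scatter. Compound 3 is estimated at 30000 nM, range 8000 nM to 120000 nM.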

Compound 3, half-maximal cytotoxic concentration: 23000 nM
Estimate against measurement, compound 3: 1.3-fold (0.12 log units) above, and the stated range covers the measured number.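

In this assay, the only step shown at this aromatic nitrogen is a 1.4-fold higher number from compound 2 to compound 3 (0.16 log units; within the scatter), so hydrogen in place of methyl leaves the number within the scatter. On the aromatic carbon, (((diethylamino)methyl)carbonyl)amino in place of hydroxy gives an at least 4.3-fold lower number from compound 1 to compound 3 (0.63 log units; beyond the scatter). That step is a bound and not a size, since compound 1 stands at a limit: the limit of > 100000 nM in this assay, at which 1 of the 3 values shown sits.

From the compounds shown here alone, whether an ethyl group or a longer chain on the same aromatic nitrogen would stay within the scatter of methyl remains open. Also open, going by these compounds, is how a carboxylic acid or a primary amine on the aromatic carbon would compare.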